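Inverting one stereocentre in a weakly cytotoxic series

A few compounds are considered here, and "the series" means these few. Any claim that something is new, unique, unknown or untested is made for them only; others in the source may bear on it.

Measured in a functional assay on K562 cells (Homo sapiens) for cytotoxicity, read by MTT assay, with a stated time of 48 h; a lower number here means a stronger inhibitor, a higher number a weaker inhibitor:

Compound 1 `CCOC(=O)[C@]1(C(=O)Nc2ccccc2Cl)C[C@@H]1c1cc(OC)c(OC)c(OC)c1` gives 19500 nM
Compound 2 `COc1cc([C@H]2C[C@]2(CO)C(=O)NCc2ccc(C)cc2)cc(OC)c1OC` gives > 100000 nM (a limit)
Compound 3 `CCOC(=O)[C@@]1(C(=O)NCc2ccc(C)cc2)C[C@@H]1c1cc(OC)c(OC)c(OC)c1` gives > 100000 nM (a limit)

Of these three compounds, only compound 1 has a measured number. Compound 3 has no number of its own, and its entry of > 100000 nM is a limit. It shares that position with one other compound, as the limit of > 100000 nM in this assay, at which 2 of the 3 values shown sit, records.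

Compound 4 `CCOC(=O)[C@]1(C(=O)NCc2ccc(C)cc2)C[C@@H]1c1cc(OC)c(OC)c(OC)c1` is the next compound to be tested. It differs from compound 3 as follows: the two compounds have the same atoms and bonds and differ only in configuration as drawn: 1 of 2 stereo elements differ; a stereocentre at a saturated ring carbon is drawn S in compound 3 and R in compound 4. In other words, a stereocentre at a saturated ring carbon is drawn S in compound 3 and R in compound 4.

For the measured compounds named here, no measured pair in this set shows what such an inversion does, and the limit for compound 3 fixes no starting number. The expected change in this assay, an at least 1.1-fold lower number from compound 3 to compound 4 (0.04 log units; that floor lies within the scatter), is therefore none beyond the scatter, in either direction. A report of only a limit would be no surprise. Compound 4 is estimated at 90000 nM, with an expected range of 30000 nM to 200000 nM.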

Compound 4, half-maximal inhibitory concentration: 20400 nM
Compound 4: middle estimate off by 4.4-fold (0.64 log units), on the high side; measured number outside the range, below it.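

In this assay, the configuration at this saturated ring carbon makes a difference, with an at least 4.9-fold lower number from compound 3 to compound 4 (0.69 log units; beyond the scatter), and the step can be placed on this one stereocentre alone because nothing else changes: the fact that compounds 3 and 4 differ only in the configuration as drawn. The ester also counts, since ethoxycarbonyl in place of hydroxymethyl gives an at least 4.9-fold lower number from compound 2 to compound 4 (0.69 log units; beyond the scatter). On the amide-type nitrogen, 4-methylbenzyl in place of 2-chlorophenyl gives a 1.0-fold higher number from compound 1 to compound 4 (0.02 log units; within the scatter), so these two groups are not told apart here.

Compound 3 carries only a limit, which leaves the full size of the inversion step open. Also open, from the compounds shown here alone, is whether a carboxylic acid in place of ethoxycarbonyl, or an amine on the benzyl ring in place of methyl, would keep or change the number seen for compound 4.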